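This account rests on a few compounds, and the source may have more. Where it says the series, first, only, none or still open, it means among the compounds named here.

Measured so far in an assay on isolated protein for inhibition of protein kinase C delta type (Homo sapiens), read by TR-FRET, with a stated time of 2 h; on this read-out higher numbers stand for weaker inhibition and lower numbers for stronger inhibition:
compound 1 `N#Cc1cnc(NCc2ccccc2C(F)(F)F)cc1N[C@H]1CC[C@@H](O)CC1` gives 4500 nM.
compound 2 `N#Cc1cnc(NCc2cnccc2C(F)(F)F)cc1NCCC1CCOCC1` gives > 10000 nM; this value is a limit of the assay, not a number.
compound 3 `N#Cc1cnc(NCc2ccccc2C(F)(F)F)cc1N[C@H]1C[C@@H](C(N)=O)C1` gives 4200 nM.

Among the two numbers shown, compound 3 holds the lowest, with compound 1 nearest; the two lie within the scatter of each other. Within the data shown here, the one step between measured compounds that differ in a single place is a 1.1-fold lower number from compound 1 to compound 3 (0.03 log units; within the scatter). Compound 2 sits at the limit of > 10000 nM in this assay, at which 1 of the 3 values shown sits, and offers no number to compare.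

Compound 4 `N#Cc1cnc(NCc2ccccc2C(F)(F)F)cc1N[C@H]1CC[C@@H](C(N)=O)CC1` differs from compound 3 by 4-carbamoylcyclohexyl in place of 3-carbamoylcyclobutyl on a nitrogen on an aromatic ring. Among the measured compounds shown here, no measured step changes the ring size of this carbamoyl-bearing group; the only neighbouring step, a 1.1-fold lower number from compound 1 to compound 3 (0.03 log units; within the scatter), exchanged a hydroxycyclohexyl for a carbamoylcyclobutyl without moving the number beyond the scatter. Compound 1 already carries a six-membered ring at this nitrogen and gives 4500 nM, close to compound 3. The expected step of a 1.1-fold lower number from compound 3 to compound 4 (0.02 log units; within the scatter) is accordingly none beyond the scatter. Compound 4 is estimated at 4000 nM, within 1500 nM to 11000 nM.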

Compound 4, half-maximal inhibitory concentration: 640 nM
Compound 4: the middle estimate sits 6.3-fold (0.80 log units) above what was measured, outside the stated range (below it).
By their numbers in this assay, from the lowest: compound 4; then compounds 3 and 1 (each within the scatter of the next). At a limit, above all of these: compound 2.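

In this assay, this position on the nitrogen proves sensitive to the substituent: with the carbamoyl kept, the ring exchange gives a 6.6-fold lower number from compound 3 to compound 4 (0.82 log units; beyond the scatter), and with the six-membered ring kept, the carbamoyl exchange gives a 7.0-fold lower number from compound 1 to compound 4 (0.85 log units; beyond the scatter). Neither feature alone goes with the lower number, as compound 3 carries the carbamoyl on a four-membered ring and compound 1 carries hydroxy on a six-membered ring, while compound 4 combines the carbamoyl with the six-membered ring. Nothing given here accounts for either step.

Open, as far as these compounds go, is whether the lower number belongs to carbamoyl itself or would also follow a carboxylic acid or an aminomethyl group on the same cyclohexyl ring. Equally open, from the compounds shown here alone, is whether it would persist in the other stereoisomer of that ring or with changes elsewhere in the core of compound 4.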